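A methyl removed from an oxygen: compound 3 to compound 4

The source may report more compounds than this note shows. Statements on the series, on what has been measured and on what is new or still open speak of the compounds shown alone.

Compound 3 `COc1cc(C)cc(-c2nn(CC#N)cc2-c2ccnc(-c3ccc(N(C)C)cc3)c2)c1` stands at the low end of the three measured values. In a functional assay on SF-295 cells (Homo sapiens) for inhibition, read by sulforhodamine B assay, with a stated time of 48 h (a lower number here means a stronger inhibitor of growth, a higher number a weaker inhibitor of growth), compound 3 gives 304 nM. Compound 1 `COc1cc(C)cc(-c2nn(CC#N)cc2-c2ccc(-c3cccc(C(C)=O)c3)nc2)c1` gives 2630 nM in this assay, a higher number that lies beyond the scatter. Compound 2 `Cc1cc(O)cc(-c2nn(CC#N)cc2-c2ccnc(-c3ccc(Oc4ccccc4)cc3)c2)c1` gives 4420 nM, the highest of the three, again beyond the scatter from compound 3. Both of these neighbours differ from compound 3 in more than one place, so no single change among the measured compounds can be read as a step.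

Compound 4 `Cc1cc(O)cc(-c2nn(CC#N)cc2-c2ccnc(-c3ccc(N(C)C)cc3)c2)c1` is not yet measured. It differs from compound 3 in one spot: hydrogen in place of methyl on an oxygen on an aromatic ring. Compound 2 carries the same 3-hydroxy-5-methylphenyl group as compound 4, but its other end also differs from compound 3, so its value shows only where it sits, not what the methyl-to-hydrogen change does on its own.

Among the compounds with values here, with no measured step for this exact change, the expectation is a modest rise in the number, possibly within the scatter, with the step from compound 3 to compound 4 estimated at a 2.0-fold higher number from compound 3 to compound 4 (0.30 log units; within the scatter). Compound 4 is expected to give 600 nM in this assay, with a range from 200 nM to 2000 nM.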

Compound 4, concentration for 50% growth inhibition: 2180 nM
Compound 4: the middle estimate sits 3.6-fold (0.56 log units) below what was measured; measured number outside the range, above it.
By their numbers in this assay, from the lowest: compound 3; then compounds 4, 1 and 2 (each within the scatter of the next, the first and the last beyond it).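

Within the data shown here, this is the first clean reading of the methoxy group: hydrogen in place of methyl on the oxygen gives a 7.2-fold higher number from compound 3 to compound 4 (0.86 log units; beyond the scatter) in this assay and lies beyond the scatter, so that one methyl accounts for much of the low number of compound 3. With the 3-hydroxy-5-methylphenyl group held constant, dimethylamino in place of phenoxy gives a 2.0-fold lower number from compound 2 to compound 4 (0.31 log units; beyond the scatter) and is also beyond the scatter, although it is the smaller of the two steps. Among these compounds, then, the change on the oxygen moves the number more than the exchange of phenoxy for dimethylamino, and the dimethylamino group alone does not keep the number low once the oxygen carries hydrogen; no measurement shown here explains either step.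

As far as these compounds go, it remains open whether a longer chain on the oxygen, such as ethyl, or an amine in place of the oxygen, would keep the number as low as methoxy does. Also unresolved is whether the same step from methoxy to hydroxy would be as large with phenoxy in place of dimethylamino.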